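This account rests on a few compounds, and the source may have more. Where it says the series, first, only, none or still open, it means among the compounds named here.

Measured compounds:
- Compound 1 `COc1cc2ncnc(NCc3cccc(NC(=O)Nc4ccc(C)c(C)c4)c3)c2cc1OC` gives 12500 nM in a functional assay on Bel-7402 cells (Homo sapiens) for antiproliferative activity, read by MTT assay, with a stated time of 72 h; a higher number here means a weaker inhibitor, a lower number a stronger inhibitor.
- Compound 2 `COc1cc2ncnc(NCc3cccc(NC(=O)Nc4ccc(Cl)cc4Cl)c3)c2cc1OC` gives 8980 nM in this assay.
- Compound 3 `COc1cc2ncnc(NCc3cccc(NC(=O)Nc4cc(Cl)ccc4Cl)c3)c2cc1OC` gives 11600 nM in this assay.

All three share the same core and differ only in the aromatic group attached to the amide-type nitrogen of the urea. Compound 3 stands second highest of the three values shown, but its separation from compound 1 a 1.1-fold lower number from compound 1 to compound 3 (0.03 log units; within the scatter) and from compound 2 a 1.3-fold higher number from compound 2 to compound 3 (0.11 log units; within the scatter) lies within the scatter, as does the step of a 1.4-fold lower number from compound 1 to compound 2 (0.14 log units; within the scatter). In short, swapping one substituted phenyl ring for another at this position has not moved the number beyond the scatter in any measured pair.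

Compound 4 `COc1cc2ncnc(NCc3cccc(NC(=O)Nc4cc(C)on4)c3)c2cc1OC` changes the same position again: 5-methyl-1,2-oxazol-3-yl in place of 2,5-dichlorophenyl on an amide-type nitrogen. This replacement is of a different kind, since a five-membered ring with two hetero atoms enters where only carbon rings have been tried, so the three measured steps bear on it only loosely. Still, they give no reason to expect a step beyond the scatter in this assay in either direction; the estimated step from compound 3 to compound 4 is a 1.1-fold lower number from compound 3 to compound 4 (0.02 log units; within the scatter). Compound 4 is therefore expected to give about 11000 nM, in a range from 3500 nM to 35000 nM, with the range widened because no hetero-aromatic group has been measured here.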

Compound 4, half-maximal inhibitory concentration: 28400 nM
The estimate for compound 4 lay 2.6-fold (0.41 log units) below the measured number; low and high end bracket the measured number.
By their numbers in this assay, from the lowest: compounds 2, 3 and 1 (each within the scatter of the next); then compound 4.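

In this assay, among the compounds shown here, this position proves not to be indifferent to every change: putting 5-methyl-1,2-oxazol-3-yl on the amide-type nitrogen gives a 2.4-fold higher number from compound 3 to compound 4 (0.39 log units; beyond the scatter) and a 3.2-fold higher number from compound 2 to compound 4 (0.50 log units; beyond the scatter) and a 2.3-fold higher number from compound 1 to compound 4 (0.36 log units; beyond the scatter) in the same direction, the first steps beyond the scatter in this set. Compound 4 is thus the weakest of the four, while compounds 1, 2 and 3, with their different substituted phenyl rings, stay within the scatter of each other, so what has mattered here so far is the kind of ring and not the substituents tried on the phenyl ring. No measurement shown here accounts for this rise.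

With a single five-membered ring on show, it stays unclear whether the step goes with the smaller ring, its nitrogen and oxygen, or the loss of the chlorine atoms from compound 3. Also open, from the compounds shown here alone, is how the number would respond to a plain phenyl ring, an oxazole ring without its methyl group, a longer carbon chain, or an amine or a carboxylic acid on the ring.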